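This account rests on a few compounds, and the source may have more. Where it says the series, first, only, none or still open, it means among the compounds named here.

Working notes on the sulfonylpiperidine series, read in a functional assay on DLD-1 cells (Homo sapiens) for antiproliferative activity, read by CellTiter-Glo, with a stated time of 72 h; on this read-out higher numbers stand for weaker inhibition and lower numbers for stronger inhibition.

Among the compounds with values here, compound 2 `Cc1cc(C)c(S(=O)(=O)N2CCC(c3ccccc3)CC2)c(C)c1` carries a phenyl on the saturated ring carbon and is the one compound of the set that returns no number: in this assay compound 2 gives > 5000 nM, a limit of the assay, so the limit of > 5000 nM in this assay, at which 1 of the 3 values shown sits, holds for it alone. The other two members are measured. Compound 1 `CCc1cc(Br)ccc1S(=O)(=O)N1CCC(N2CCC(C)CC2)CC1` bears a 4-methylpiperidin-1-yl on that same carbon and in this assay gives 0.6 nM. Compound 3 `CC1CCN(C2CCN(S(=O)(=O)c3cnc(Cl)s3)CC2)CC1` keeps the 4-methylpiperidin-1-yl but has a chlorothiazole sulfonyl, and in this assay gives 1800 nM; the pair of values for compound 1 and compound 3 sit far apart.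

The step to compound 4 `Cc1cc(C)c(S(=O)(=O)N2CCC(N3CCC(O)CC3)CC2)c(C)c1` is 4-hydroxypiperidin-1-yl in place of phenyl on a saturated ring carbon. The trimethylphenyl sulfonyl of compound 2 is unchanged; only the group on the saturated ring carbon is swapped, from an all-carbon ring to a piperidine ring bearing a hydroxyl.

Within the data shown here, no measured step in this assay connects these two compounds directly. Still, the measured compounds that carry a piperidin-1-yl on this carbon, compound 1 at 0.6 nM and compound 3 at 1800 nM, both give numbers, whereas compound 2 with phenyl does not. A step toward stronger inhibition, larger than the scatter, is therefore expected for compound 4. The estimate for compound 4 is 300 nM, spanning 30 nM to 4000 nM, which means an expected step of an at least 16-fold lower number from compound 2 to compound 4 (1.22 log units; beyond the scatter).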

Compound 4, half-maximal inhibitory concentration: 106 nM
Estimate against measurement, compound 4: 2.8-fold (0.45 log units) above, and the stated range covers the measured number.
By their numbers in this assay, from the lowest: compound 1; then compound 4; then compound 3. At a limit, above all of these: compound 2.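

Within this assay, the series now has its first readable step at this saturated ring carbon, with the trimethylphenyl sulfonyl held fixed: 4-hydroxypiperidin-1-yl in place of phenyl gives an at least 47-fold lower number from compound 2 to compound 4 (1.67 log units; beyond the scatter) on this read-out. A measured number with a piperidine ring on this carbon is thus no longer confined to the 4-methylpiperidin-1-yl compounds, although compound 4 differs from compound 1 and from compound 3 in more than one place, so steps to those two cannot be read. The step has only a lower bound on its size, because compound 2 stands at a limit of the assay: the limit of > 5000 nM in this assay, at which 1 of the 4 values shown sits.

As far as these compounds go, the change swaps the all-carbon aromatic ring for a piperidine ring and adds a hydroxyl in a single move, so the share of the ring nitrogen and the share of the hydroxyl in the step remain open. Also open, from the compounds shown here alone, is how compound 4 would compare with an amine or a carboxylic acid in place of its hydroxyl, or with a morpholine ring on the same carbon.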